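From Phenyl to 3,4-Dichlorophenyl: An Expected Loss

The source may report more compounds than this note shows. Statements on the series, on what has been measured and on what is new or still open speak of the compounds shown alone.

In an in vitro assay on cells for inhibition of Amine oxidase [flavin-containing] B (Homo sapiens), read by fluorescence and Amplex Red, with stated times of 30 min and 45 min (on this read-out higher numbers stand for weaker inhibition and lower numbers for stronger inhibition), compound 3 `O=C(C/C=C/c1ccccc1)Nc1nc2ccccc2c(=O)s1` gives 39.8 nM, the lowest number among those measured. Compound 1 `COc1cccc(/C=C/CC(=O)Nc2nc3ccccc3c(=O)s2)c1` gives 238 nM. For compound 2 `O=C(C/C=C/c1cccc(Cl)c1)Nc1nc2ccccc2c(=O)s1` the assay reports only a limit, > 1000 nM, which is the limit of > 1000 nM in this assay, at which 1 of the 3 values shown sits. The measured steps are a 6.0-fold lower number from compound 1 to compound 3 (0.78 log units; beyond the scatter), an at least 4.2-fold higher number from compound 1 to compound 2 (0.62 log units; beyond the scatter) and an at least 25-fold lower number from compound 2 to compound 3 (1.40 log units; beyond the scatter). Compound 4 `O=C(C/C=C/c1ccc(Cl)c(Cl)c1)Nc1nc2ccccc2c(=O)s1` differs from compound 3 by 3,4-dichlorophenyl in place of phenyl on a double-bonded chain carbon bound to a double-bonded chain carbon. The step bearing most closely on this change is an at least 25-fold lower number from compound 2 to compound 3 (1.40 log units; beyond the scatter), which removed a chloro from an aromatic carbon; compound 4 brings in two chlorines. The number for compound 4 is therefore expected to rise, a step of a 50-fold higher number from compound 3 to compound 4 (1.70 log units; beyond the scatter), and may again reach the limit. The estimate for compound 4 is 2000 nM, within 300 nM to 15000 nM.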

Compound 4, half-maximal inhibitory concentration: > 10000 nM
Compound 4 was reported as a limit (the forecaster's own chance of this, stated with the estimate: 70%); at least 5.0-fold (0.69 log units) between middle value and limit.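

In this assay the 3,4-dichlorophenyl group in this place leaves almost nothing of the inhibition seen with phenyl, with an at least 250-fold higher number from compound 3 to compound 4 (2.40 log units; beyond the scatter), and it also falls well short of 3-methoxyphenyl, with an at least 42-fold higher number from compound 1 to compound 4 (1.62 log units; beyond the scatter). The value for compound 4 is a limit, not a number: the limit of > 10000 nM in this assay, at which 1 of the 4 values shown sits. Compound 2 also stands at a limit, and the step from it to compound 4 cannot be read: the limit of > 1000 nM in this assay, at which 1 of the 4 values shown sits.

Going by these compounds, whether the added chloro deepens the loss therefore stays open. So does whether an amine or a carboxylic acid on this phenyl would bring the number back towards that of compound 3.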